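A few compounds are considered here, and "the series" means these few. Any claim that something is new, unique, unknown or untested is made for them only; others in the source may bear on it.

Working notes on the thiourea series.

Compound 1 `NC(=S)Nc1cccc(OCCCCCN2CCN(c3cccc4ccccc34)C2=O)c1` gives 15000 nM in an ADME assay on Huh-7 cells (Homo sapiens) for cytotoxicity; a higher number here means that more compound is tolerated, a lower number that less compound is tolerated. Compound 2 `NC(=S)Nc1cccc(OCCCCCCCCNC(=S)Nc2cc(Cl)cc(Cl)c2)c1` gives 12000 nM in this assay. For compound 3 `NC(=S)Nc1cccc(OCCCCCCCCNC(=S)Nc2ccccc2)c1` the result in this assay is a limit of the assay, > 50000 nM, not a number; this is the limit of > 50000 nM in this assay, at which 1 of the 3 values shown sits. Within the data shown here, the one step that can be followed within the measured set is an at least 4.1-fold higher number from compound 2 to compound 3 (0.61 log units; beyond the scatter), so taking the two chlorines off the terminal aryl ring moved the number up, and the true size of that step is hidden behind the limit.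

Compound 4 `NC(=S)Nc1cccc(OCCCCCCCCNC(=S)Nc2ccc(Br)cc2)c1` differs from compound 3 in a single place: bromo in place of hydrogen on an aromatic carbon. This puts one halogen back onto the ring that in compound 2 carried two, so the step in this assay bearing on it is the same one, an at least 4.1-fold higher number from compound 2 to compound 3 (0.61 log units; beyond the scatter), read in the opposite direction. A drop from the limit of compound 3 toward the number of compound 2 is therefore expected, though a single bromo is not two chloro groups, and compound 3 itself has no firm number to drop from. The estimate for compound 4 in this assay is 30000 nM, with a range of 12000 nM to 60000 nM, which is expected to mean a step of an at least 1.6-fold lower number from compound 3 to compound 4 (0.22 log units; that floor lies within the scatter).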

Compound 4, half-maximal cytotoxic concentration: 18000 nM
For compound 4 the middle estimate is 1.7-fold (0.22 log units) above the measured one; the measured number falls inside the stated range.
By their numbers in this assay, from the lowest: compounds 2, 1 and 4 (each within the scatter of the next). At a limit, above all of these: compound 3.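

In this assay, a single bromo on an aromatic carbon, para to a large group, is enough to give an at least 2.7-fold lower number from compound 3 to compound 4 (0.44 log units; beyond the scatter), so the terminal ring does not need two chlorines for less compound to be tolerated. The two halogenated rings are not separated, with a 1.5-fold higher number from compound 2 to compound 4 (0.18 log units; within the scatter): one bromo and two chloro groups leave the number in the same range, and these compounds give no sign that a second halogen adds anything. Compound 3 stands at a limit of the assay, not a number, so the step from it gives only a floor and the full effect of the bromo remains unknown: the limit of > 50000 nM in this assay, at which 1 of the 4 values shown sits.

Going by these compounds, it remains open whether this fall belongs to halogens or to any group at that place on the ring, since a fluoro, a methoxy, a nitrile or a carboxylic acid there would tell these readings apart. On these data alone, it is also open whether the same bromo would lower the number to a similar degree on a shorter or longer chain.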